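Cycloheptyl for 4-nitrophenyl at the ring amine nitrogen

A few compounds are considered here, and "the series" means these few. Any claim that something is new, unique, unknown or untested is made for them only; others in the source may bear on it.

Going by the values given here, compound 1 `Nc1scc(CN2CCN(c3ccc([N+](=O)[O-])cc3)CC2)c1C(=O)c1ccc(Cl)cc1` gives -8.3% in a functional assay on CHO cells with adenosine receptor A1 (Homo sapiens) as the target, read by cAMP accumulation and immunoassay, with a stated time of 6 min, tested at 1 uM (a higher number here means a weaker effect of the compound at the concentration tested, a lower number a stronger effect), the highest of the two numbers measured so far; compound 2 `Nc1scc(CN2CCN(c3cccc(F)c3)CC2)c1C(=O)c1cccc(C(F)(F)F)c1` gives -35%, a value that lies below compound 1 by more than the usual scatter. Compound 3 `Nc1scc(CN2CCN(C3CCCCCC3)CC2)c1C(=O)c1ccc(Cl)cc1` differs from compound 1 in one place: cycloheptyl in place of 4-nitrophenyl on an amine nitrogen in a ring. Among the compounds with values here, no measured pair isolates this change, so its direction rests on nothing measured; a modest move toward a lower number, rather than none, is expected. For compound 3 the value in this assay is estimated at -15%, within -45% to 15%, the expected step being a number 6.7 percentage points lower from compound 1 to compound 3 (within the scatter).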

Compound 3, a percentage reported as activity, at one concentration (the size of the read-out at that concentration, not a potency): 3.7%
Compound 3: middle estimate off by 18.7 percentage points, on the low side; measured number inside the range.
By their numbers in this assay, from the lowest: compound 2; then compound 1; then compound 3.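

In this assay, going by these compounds alone, the change to cycloheptyl on the amine nitrogen in the ring gives a number 12 percentage points higher from compound 1 to compound 3 (beyond the scatter) as the first single-change step at this position. The read-out at this nitrogen therefore depends on the group it carries, with the rest of compound 1 held fixed. No measurement available here accounts for the step.

Open, going by these compounds, is whether a smaller ring such as cyclopentyl, or a benzyl group, at this nitrogen falls on the same side of compound 1. Also open, on these data alone, is whether the step persists with trifluoromethyl in place of the chlorine on the shared core.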